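The compounds below may be only part of what the source reports. "The series", "measured", "known", "first", "only" and "open" are said of these compounds alone.

In a functional assay on K562 cells (Homo sapiens) for cytotoxicity, read by ELISA, with a stated time of 4 days (a higher number here means a weaker inhibitor, a lower number a stronger inhibitor), compound 1 `Cc1ccsc1-c1cc(-c2ccco2)cc(-c2ccc(Cl)cc2)n1` gives 20700 nM and compound 2 `Cc1ccsc1-c1cc(-c2ccc(Cl)o2)cc(-c2cccc(Cl)c2)n1` gives 13400 nM as its read-out. Within the data shown here, these two numbers lie within the scatter of each other, so compound 2 sits level with the only other measured compound. Compound 3 `Cc1ccsc1-c1cc(-c2ccc(Cl)o2)cc(-c2ccc(Cl)cc2)n1` has the same atoms as compound 2, joined differently: 4-chlorophenyl in place of 3-chlorophenyl on an aromatic carbon, next to the ring nitrogen 4-chlorophenyl in place of 3-chlorophenyl on an aromatic carbon and nothing else altered. Among the measured compounds shown here, no step between measured compounds that differ in one place is available, so the series gives no direct reading on this swap. In this assay no change beyond the scatter is expected and no direction is favoured, the estimated step being a 1.0-fold higher number from compound 2 to compound 3 (0.02 log units; within the scatter) in size. For compound 3 the estimated value is 14000 nM with 6500 nM to 30000 nM as the expected range.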

Compound 3, half-maximal inhibitory concentration: 15600 nM
Estimate against measurement, compound 3: 1.1-fold (0.05 log units) below, and the stated range covers the measured number.
By their numbers in this assay, from the lowest: compounds 2, 3 and 1 (each within the scatter of the next).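

In this assay, among these compounds, the swap of 3-chlorophenyl for 4-chlorophenyl on the aromatic carbon next to the ring nitrogen gives a 1.2-fold higher number from compound 2 to compound 3 (0.07 log units; within the scatter) and is the first direct reading at this position; the chlorine placement on this aryl group does not separate the two compounds. Compound 3 also connects to compound 1 through a single change, chloro in place of hydrogen on an aromatic carbon, with a 1.3-fold lower number from compound 1 to compound 3 (0.12 log units; within the scatter) as the result, so this change also stays within the scatter. Nothing measured on these compounds accounts for either reading.

On these data alone, whether this aryl position responds to anything other than chlorine remains open, for example an amine or a carboxylic acid in place of the chlorine. With all three compounds level, no place on the shared core has yet been shown to shift the read-out.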